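A few compounds are considered here, and "the series" means these few. Any claim that something is new, unique, unknown or untested is made for them only; others in the source may bear on it.

Measured so far:
- compound 1 `COc1ccccc1N1C(=O)C(C)SC1c1cccc(C(=O)NCCCCc2ccccc2)c1`: 45.1 nM
- compound 2 `O=C(NCCCCc1ccccc1)c1cccc(C2SCC(=O)N2c2ccc(-c3ccccc3)cc2)c1`: only a limit, > 1000 nM
- compound 3 `COc1ccccc1N1C(=O)CSC1c1cc(F)cc(C(=O)O)c1`: only a limit, > 1000 nM

In a functional assay on HOS-TE85 cells (Homo sapiens) for inhibition, read by CCK-8 assay, with a stated time of 72 h (on this read-out lower numbers stand for stronger inhibition and higher numbers for weaker inhibition), compound 1 gives 45.1 nM. Compound 2 gives no number in this assay but only a limit, > 1000 nM. Compound 3 likewise reaches only a limit, > 1000 nM. Compound 2 therefore stands at the bottom of what is shown: it sits at the limit of > 1000 nM in this assay, at which 2 of the 3 values shown sit, and no number places it any more closely. Within the data shown here, no pair of the measured compounds differs in a single place, so no measured step can be read off.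

Compound 4 `COc1cc(F)ccc1N1C(=O)CSC1c1cccc(C(=O)NCCCCc2ccccc2)c1` has not yet been measured. Against compound 2 the change is 4-fluoro-2-methoxyphenyl in place of 4-phenylphenyl on an amide-type nitrogen in a ring. With this change compound 4 comes to resemble compound 1 rather than compound 2 in the group on the amide-type nitrogen in a ring, while keeping the amide side chain that compound 3 lacks. Compound 1 gives 45.1 nM, and compound 4 is expected to move in that direction, a step from compound 2 of an at least 11-fold lower number from compound 2 to compound 4 (1.04 log units; beyond the scatter), well beyond the scatter. Compound 4 is estimated at 90 nM, between 30 nM and 400 nM.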

Compound 4, half-maximal inhibitory concentration: 71.1 nM
Compound 4: the middle estimate sits 1.3-fold (0.10 log units) above what was measured, within the range that was stated.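

In this assay, the group on the amide-type nitrogen in a ring proves decisive for this pair: with the amide side chain and the rest of the structure unchanged, 4-fluoro-2-methoxyphenyl in place of 4-phenylphenyl gives an at least 14-fold lower number from compound 2 to compound 4 (1.14 log units; beyond the scatter). This is the only step shown between compounds that differ in one place, so it is the only direct reading of this position, and a large one. The step has a floor but no upper end, with compound 2 held only at a limit of the assay: the limit of > 1000 nM in this assay, at which 2 of the 4 values shown sit.

The compounds shown leave open whether the methoxy group, the fluorine or both together carry this step. They also leave open how a plain phenyl or a 4-aminophenyl group on the same nitrogen would read.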